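Trichlorophenyl for dichlorophenyl on the core of compound 1

The source may hold more compounds than are shown below. What is called first, only, known or untested is meant among the compounds shown, and "the series" means these compounds.

Measured so far in a functional assay on HL-60 cells (Homo sapiens) for antiproliferative activity, read by MTT assay, with a stated time of 72 h; on this read-out lower numbers stand for stronger inhibition and higher numbers for weaker inhibition:
Compound 1 `NC1=NC2(CCSCC2)N(OCCCOc2cccc(Cl)c2Cl)C(N)=N1` gives 30 nM.
Compound 2 `NC1=NC2(CCOCC2)N(OCCCOc2ccccc2Cl)C(N)=N1` gives 660 nM.
Compound 3 `NC1=NC2(CCOCC2)N(OCCCOc2cccc(Br)c2)C(N)=N1` gives 560 nM.

Compound 1 gives the lowest number of the three; its gaps to compound 2 and to compound 3 are both beyond the scatter, so within this set it is the most potent. Compound 4 `NC1=NC2(CCSCC2)N(OCCCOc2cc(Cl)c(Cl)cc2Cl)C(N)=N1` is not yet measured. It differs from compound 1 in one place: 2,4,5-trichlorophenyl in place of 2,3-dichlorophenyl on an oxygen on a saturated carbon.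

Going by the values given here, the only measured step that touches the aryl group is a 1.2-fold lower number from compound 2 to compound 3 (0.07 log units; within the scatter), and it sits on a core that is not the core of compound 1; no step tests the new aryl on that core. On this basis a step of a 1.3-fold higher number from compound 1 to compound 4 (0.12 log units; within the scatter) is expected, i.e. none beyond the scatter. Compound 4 is estimated at 40 nM, with a range of 12 nM to 130 nM in this assay .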

Compound 4, half-maximal inhibitory concentration: 730 nM
Beside the measured number, compound 4's estimate is 18-fold (1.26 log units) below it, and the stated range ends below it.
By their numbers in this assay, from the lowest: compound 1; then compounds 3, 2 and 4 (each within the scatter of the next).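

On the core of compound 1, the aryl group on the oxygen is sensitive to change in this assay: 2,4,5-trichlorophenyl in place of 2,3-dichlorophenyl gives a 24-fold higher number from compound 1 to compound 4 (1.39 log units; beyond the scatter). Going by these compounds alone, this is the first aryl step beyond the scatter, and it is large. No evidence at hand bears on this loss.

This single step cannot separate the added chlorine from the changed chlorine pattern. Also open, from the compounds shown here alone, is how a carboxylic acid or an amine in place of the 2,3-dichlorophenyl would read on this core.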